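A few compounds are considered here, and "the series" means these few. Any claim that something is new, unique, unknown or untested is made for them only; others in the source may bear on it.

Working notes on the series.

Compound 1 `CN1CCN(c2ccc(C3=NN(C(=O)c4ccc(F)cc4)C(c4ccc(N(C)C)cc4)C3)cc2)CC1`, compound 2 `Cc1ccc(S(=O)(=O)N2N=C(c3ccc(N4CCN(C)CC4)cc3)CC2c2ccc(N(C)C)cc2)cc1` and compound 3 `CN1CCN(c2ccc(C3=NN(S(=O)(=O)c4ccc(Br)cc4)C(c4ccc(N(C)C)cc4)C3)cc2)CC1` share one core and differ only in the group on the ring nitrogen and its aryl substituent. In a functional assay on MDA-MB-231 cells (Homo sapiens) for inhibition, read by sulforhodamine B assay, tested at 10 uM (a higher number here means more inhibition at the concentration tested (going by the name of the read-out), a lower number less inhibition), compound 1 gives 3.5%, compound 2 gives 10.7% and compound 3 gives 23.7%. Compound 2 holds the second highest of the three numbers: the step of a number 7.2 percentage points higher from compound 1 to compound 2 (within the scatter) is within the scatter, while a number 13 percentage points higher from compound 2 to compound 3 (beyond the scatter) and a number 20.2 percentage points higher from compound 1 to compound 3 (beyond the scatter) are beyond it, both modest.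

Compound 4 `Cc1ccc(S(=O)(=O)N2N=C(c3ccc(-n4ccnc4)cc3)CC2c2ccc(N(C)C)cc2)cc1` is not yet measured. It differs from compound 2 by 1H-imidazol-1-yl in place of 4-methylpiperazin-1-yl on an aromatic carbon. Among the measured compounds shown here, none of the measured steps touches this position; all three concern the sulfonyl or carbonyl group and its aryl substituent, so they give no guide to this change. The expectation is therefore a step of about a number 0.3 percentage points higher from compound 2 to compound 4 (within the scatter), not beyond the scatter. Compound 4 is estimated at 11% in this assay, with a range from 0% to 28%.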

Compound 4, a percentage reported as inhibition, at one concentration (the size of the read-out at that concentration, not a potency): 50.8%
Compound 4: the middle estimate sits 39.8 percentage points below what was measured, outside the stated range (above it).
By their numbers in this assay, from the lowest: compounds 1 and 2 (each within the scatter of the next); then compound 3; then compound 4.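

Among the compounds shown here, the position on an aromatic carbon, para to a large group, is the first to show a large change: in this assay there is a number 40.1 percentage points higher from compound 2 to compound 4 (beyond the scatter), a bigger step than any printed for the sulfonyl or carbonyl group and its aryl substituent. The change replaces a six-membered non-aromatic ring with a five-membered aromatic ring, while the counts of hydrogen-bond donors and acceptors stay the same, so those counts do not separate the two compounds. Nothing available explains the size of this step.

Only this one pair is shown at this position, so it remains open whether 1H-imidazol-1-yl gives a similar step with (4-bromophenyl)sulfonyl or (4-fluorophenyl)carbonyl on the ring nitrogen. A morpholine or a pyrazole at the same place could help show whether the aromatic ring goes with the higher number.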